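Replacing an Aryl Urea with a Benzyl Urea

This account rests on a few compounds, and the source may have more. Where it says the series, first, only, none or still open, it means among the compounds named here.

Compound 1 `O=C(Nc1cccc(Br)c1)N[C@@H]1C2CCN(CC2)[C@@H]1Cc1cccnc1` carries a 3-bromophenyl group on one nitrogen of a urea that is attached to the shared core. In an assay on a protein complex for binding affinity to Neuronal acetylcholine receptor; alpha4/beta2 (Homo sapiens) (on this read-out lower numbers stand for stronger inhibition and higher numbers for weaker inhibition), compound 1 gives > 10000 nM, which is a limit of the assay rather than a number. Two close relatives share this fate. Compound 2 `CSc1ccc(NC(=O)N[C@@H]2C3CCN(CC3)[C@@H]2Cc2cccnc2)cc1` has a 4-(methylsulfanyl)phenyl group in that place, and in this assay compound 2 gives > 10000 nM, again only a limit. Compound 3 `O=C(Nc1cccc(F)c1)N[C@@H]1C2CCN(CC2)[C@@H]1Cc1cccnc1` has a 3-fluorophenyl group there, and in this assay compound 3 gives > 10000 nM, also a limit. Because the limit of > 10000 nM in this assay, at which 3 of the 3 values shown sit, none of the steps among these three can be read: a step that the two limits leave unreadable from compound 1 to compound 2, a step that the two limits leave unreadable from compound 1 to compound 3 and a step that the two limits leave unreadable from compound 2 to compound 3 all remain of unknown size.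

Compound 4 `O=C(NCc1ccc(Br)cc1)N[C@@H]1C2CCN(CC2)[C@@H]1Cc1cccnc1` differs from compound 1 in one place: 4-bromobenzyl in place of 3-bromophenyl on an amide-type nitrogen. Within the data shown here, no measured step speaks to a benzyl group on this nitrogen, so the evidence offers no size and no direction for the change, and nothing beyond the scatter can be predicted from it. With every measured neighbour sitting at the limit, compound 4 is expected to give 15000 nM in this assay, with a range from 5000 nM to 50000 nM. That corresponds to an expected step that the limit leaves unreadable from compound 1 to compound 4, most likely reported once more only as a limit.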

Compound 4, inhibition constant: > 10000 nM
Compound 4 ended at the assay's limit (the forecaster's own chance of this, stated with the estimate: 85%); the middle value does not contradict the limit.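

In this assay compound 4 gives > 10000 nM, which is a limit of the assay and not a number. The steps to compound 4 from compound 1, compound 2 and compound 3 therefore cannot be read, because all four compounds share one limit: the limit of > 10000 nM in this assay, at which 4 of the 4 values shown sit. The compounds shown leave open how strongly any of them binds, and whether 4-bromobenzyl differs from the other groups on this nitrogen.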